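Swapping methyl for iodo on compound 3

A few compounds are considered here, and "the series" means these few. Any claim that something is new, unique, unknown or untested is made for them only; others in the source may bear on it.

In a functional assay on HeLa cells (Homo sapiens) for inhibition, read by sulforhodamine B assay (a higher number here means a weaker inhibitor, a lower number a stronger inhibitor), three compounds sharing one core have been measured, and they differ only in the group on an amine nitrogen. Compound 1 `O=C1C=C(NCc2ccccc2)C(=O)c2c1nc1n2[C@H]2OC[C@@H](O)[C@H]2OC1`, with benzyl there, gives > 8000 nM, which is a limit of the assay. Compound 2 `O=C1C=C(NC2CCCCC2)C(=O)c2c1nc1n2[C@H]2OC[C@@H](O)[C@H]2OC1`, with cyclohexyl, gives > 16000 nM, again a limit. For the measured compounds named here, compound 3 `Cc1ccc(NC2=CC(=O)c3nc4n(c3C2=O)[C@H]2OC[C@@H](O)[C@H]2OC4)cc1`, with 4-methylphenyl, gives 3860 nM, the only actual number of the three and the strongest result. The two steps that reach it are an at least 2.0-fold lower number from compound 1 to compound 3 (0.31 log units; beyond the scatter) and an at least 4.1-fold lower number from compound 2 to compound 3 (0.61 log units; beyond the scatter). Both start from a limit, so they give only a minimum size.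

Compound 4 `O=C1C=C(Nc2ccc(I)cc2)C(=O)c2c1nc1n2[C@H]2OC[C@@H](O)[C@H]2OC1` changes one small group: iodo in place of methyl on an aromatic carbon, para to a large group. Neither measured step alters a group on that aromatic ring, so neither gives a size for this swap. Going by the values given here, the only anchor is compound 3 at 3860 nM, and no change beyond the scatter is expected. The estimated step is a 1.3-fold lower number from compound 3 to compound 4 (0.11 log units; within the scatter). For compound 4 the expected value is 3000 nM, with an estimated range of 1000 nM to 9000 nM.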

Compound 4, half-maximal inhibitory concentration: 4070 nM
Estimate against measurement, compound 4: 1.4-fold (0.13 log units) below; low and high end bracket the measured number.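

In this assay, for the compounds shown here, the swap of methyl for iodo on an aromatic carbon, para to a large group, gives a 1.1-fold higher number from compound 3 to compound 4 (0.02 log units; within the scatter) and so offers the first direct look at this spot on the ring: for this one pair of groups, the two values cannot be told apart. Against cyclohexyl, the 4-iodophenyl group gives an at least 3.9-fold lower number from compound 2 to compound 4 (0.59 log units; beyond the scatter) and this is only a minimum size, set by the limit for compound 2: the limit of > 16000 nM in this assay, at which 1 of the 4 values shown sits. Against benzyl, it gives an at least 1.9-fold lower number from compound 1 to compound 4 (0.29 log units; that floor lies within the scatter) and so even the smallest size this step could have cannot be told from scatter, and that step too is only a minimum, set by the limit for compound 1: the limit of > 8000 nM in this assay, at which 1 of the 4 values shown sits.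

As far as these compounds go, two groups on one ring carbon say little about that spot in general, so it remains open whether a methoxy, an amine or a carboxylic acid there would also match compound 3. From the compounds shown here alone, it also remains open whether iodo on another carbon of the ring would give a value like that of compound 4.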